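Dichlorophenyl Pyrazoline Thiocarboxamide in Colon Carcinoma Cells

A few compounds are considered here, and "the series" means these few. Any claim that something is new, unique, unknown or untested is made for them only; others in the source may bear on it.

Measured compounds in a functional assay on HCT-116 cells (Homo sapiens) for antiproliferative activity, read by MTT assay, with a stated time of 48 h; a lower number here means a stronger inhibitor of growth, a higher number a weaker inhibitor of growth:
compound 1 `FC(F)(F)c1ccc(C2=NN(C(=S)Nc3ccccc3)C(c3ccc4c(c3)OCCO4)C2)cc1`, for which compound 1 gives 112000 nM
compound 2 `O=[N+]([O-])c1ccc(C2=NN(C(=S)Nc3ccccc3)C(c3ccc4c(c3)OCCO4)C2)cc1`, for which compound 2 gives > 200000 nM, a limit of the assay
compound 3 `S=C(Nc1ccccc1)N1N=C(c2cccc(Cl)c2)CC1c1ccc2c(c1)OCCO2`, for which compound 3 gives 138000 nM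

Compound 3 stands at the highest of the two numbers given, with compound 1 nearest to it; the step of a 1.2-fold higher number from compound 1 to compound 3 (0.09 log units; within the scatter) lies within the scatter. The value of compound 2 is a limit of the assay (the limit of > 200000 nM in this assay, at which 1 of the 3 values shown sits). The step of an at least 1.4-fold lower number from compound 2 to compound 3 (0.16 log units; that floor lies within the scatter) has a floor that also lies within the scatter, as does the step of an at least 1.7-fold higher number from compound 1 to compound 2 (0.25 log units; that floor lies within the scatter).

Compound 4 `S=C(Nc1ccccc1)N1N=C(c2ccc(Cl)c(Cl)c2)CC1c1ccc2c(c1)OCCO2` differs from compound 3 in one place: chloro in place of hydrogen on an aromatic carbon. For the measured compounds named here, no measured step covers this change. The steps already seen all exchange the whole group on the carbon with a double bond to nitrogen, and none of them moves the numbers beyond the scatter. So the step of a 1.1-fold lower number from compound 3 to compound 4 (0.03 log units; within the scatter) is expected to stay within the scatter, with no direction claimed.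

In this assay compound 4 is therefore estimated to give 130000 nM, most likely between 60000 nM and 300000 nM.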

Compound 4, concentration for 50% growth inhibition: 125000 nM
For compound 4 the middle estimate is 1.0-fold (0.02 log units) above the measured one; the range from low to high includes it.
By their numbers in this assay, from the lowest: compounds 1, 4 and 3 (each within the scatter of the next). At a limit, above all of these: compound 2.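

In this assay, for the compounds shown here, the step of a 1.1-fold lower number from compound 3 to compound 4 (0.04 log units; within the scatter) is the first here that adds a single atom to the aryl group rather than exchanging that group whole, and a chloro para to a large group and ortho to a chloro group leaves the number within the scatter. The steps of a 1.1-fold higher number from compound 1 to compound 4 (0.05 log units; within the scatter) and an at least 1.6-fold lower number from compound 2 to compound 4 (0.20 log units; that floor lies within the scatter) also stay within the scatter, the second only as a floor, so that 3-chlorophenyl, 3,4-dichlorophenyl and 4-(trifluoromethyl)phenyl in compounds 3, 4 and 1 give numbers that cannot be told apart in this assay. The value of compound 2 is a limit and not a number: the limit of > 200000 nM in this assay, at which 1 of the 4 values shown sits.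

The compounds shown leave open whether an amine, a hydroxyl or a carboxylic acid on this aromatic ring would move the number beyond the scatter. They also leave open what a change elsewhere on the shared core would do, such as a methyl or a longer chain in place of the phenyl on the thiocarboxamide.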